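The source may report more compounds than this note shows. Statements on the series, on what has been measured and on what is new or still open speak of the compounds shown alone.

Of the compounds shown here, two built on one shared core have been measured for how small an amount of them is needed to switch on the receptor. Compound 1 `Cc1ccc(OCC(=O)N(Cc2cccs2)c2ccccn2)cc1` in an assay on HEK293 cells for agonist activity at transient receptor potential cation channel subfamily M member 8 (Homo sapiens), read by fluorescence and calcium flux, with a stated time of 15 min (on this read-out higher numbers stand for an effect only at larger amounts of compound and lower numbers for an effect already at smaller amounts), gives 200 nM. Compound 2 `CCC(C)N(Cc1cccs1)C(=O)COc1ccc(C)cc1` in this assay gives 2000 nM, the higher of the two numbers, set apart by a 10-fold higher number from compound 1 to compound 2 (1.00 log units; beyond the scatter), a step that came from putting sec-butyl in place of pyridin-2-yl on the amide-type nitrogen. Compound 3 `Cc1ccc(OCC(=O)N(Cc2cccs2)C2COC2)cc1` has not yet been measured. It differs from compound 2 by oxetan-3-yl in place of sec-butyl on an amide-type nitrogen. For the measured compounds named here, only one measured step concerns this nitrogen, a 10-fold higher number from compound 1 to compound 2 (1.00 log units; beyond the scatter), and it exchanged pyridin-2-yl for sec-butyl rather than sec-butyl for a small saturated ring, so it guides the direction only loosely. A modest step of uncertain direction is expected, a 1.5-fold higher number from compound 2 to compound 3 (0.18 log units; within the scatter). Compound 3 is therefore estimated to give 3000 nM in this assay, somewhere between 700 nM and 12000 nM.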

Compound 3, half-maximal effective concentration: 23000 nM
Compound 3: the middle estimate sits 7.7-fold (0.88 log units) below what was measured; measured number outside the range, above it.
By their numbers in this assay, from the lowest: compound 1; then compound 2; then compound 3.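

On this amide-type nitrogen, two groups with the same count of 4 heavy atoms are far from interchangeable: in this assay, oxetan-3-yl in place of sec-butyl, which adds a four-membered ring and a hydrogen-bond acceptor, gives a 12-fold higher number from compound 2 to compound 3 (1.06 log units; beyond the scatter). Set against pyridin-2-yl, the same group gives a 120-fold higher number from compound 1 to compound 3 (2.06 log units; beyond the scatter), so among these three compounds a change at this one position alone moves the number widely, with pyridin-2-yl lowest and oxetan-3-yl highest. Nothing available here says what lies behind this rise.

Still open, as far as these compounds go, is whether the ring itself or its oxygen matters more, a question that cyclobutyl on the same nitrogen would help to separate. Also open, from the compounds shown here alone, is how phenyl would compare with pyridin-2-yl at this position.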